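The source may hold more compounds than are shown below. What is called first, only, known or untested is meant among the compounds shown, and "the series" means these compounds.

Among the compounds with values here, in a functional assay on L1210 cells (Mus musculus) for inhibition (a higher number here means a weaker inhibitor, a lower number a stronger inhibitor), compound 2 `C#CCN(Cc1ccc2nc(C)nc(O)c2c1)c1ccc(C(=O)c2ccccc2)cc1` gives 7700 nM, the only actual number available for this series. Compound 1 `C#CCN(Cc1ccc2nc(C)nc(O)c2c1)c1ccc(C#N)cc1` reports > 5000 nM, which is a limit of the assay and not a number. Compound 3 `C#CCN(Cc1ccc2nc(C)nc(O)c2c1)c1ccc(S(N)(=O)=O)cc1` keeps the shared core of compound 2 and differs from it by sulfamoyl in place of benzoyl on an aromatic carbon, para to a large group. Within the data shown here, only one measured step bears on this change. That step, a step that the limit leaves unreadable from compound 1 to compound 2, has no readable size, so it offers neither a magnitude nor a direction for compound 3, and no step beyond the scatter is expected in this assay. The estimated outcome is a 1.0-fold higher number from compound 2 to compound 3 (0.02 log units; within the scatter). Compound 3 is expected at 8000 nM, with an estimated range of 2500 nM to 25000 nM.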

Compound 3, half-maximal inhibitory concentration: 20000 nM
The estimate for compound 3 lay 2.5-fold (0.40 log units) below the measured number; measured number inside the range.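

In this assay, this position now has its first readable step: replacing benzoyl with sulfamoyl gives a 2.6-fold higher number from compound 2 to compound 3 (0.41 log units; beyond the scatter). The change at this aromatic carbon, para to a large group, therefore moves the read-out beyond the scatter, and the weaker inhibitor of the pair carries the sulfamoyl group. The steps from compound 1 cannot be read, since its value is a limit: the limit of > 5000 nM in this assay, at which 1 of the 3 values shown sits.

This single step swaps a ring-bearing group for one with no ring and also adds a hydrogen-bond donor, so the compounds shown cannot say which of these differences matters. Going by these compounds, how the cyano group of compound 1 ranks against the other two groups remains open, as does whether an amine or a carboxylic acid at this carbon would give a stronger inhibitor.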